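Bromo for Fluoro on a Weakly Cytotoxic Pyridyl Ketone Pair

A few compounds are considered here, and "the series" means these few. Any claim that something is new, unique, unknown or untested is made for them only; others in the source may bear on it.

Two compounds sharing one core have so far been run in a functional assay on PC-3 cells (Homo sapiens) for cytotoxicity, read by sulforhodamine B assay, with a stated time of 48 h; on this read-out lower numbers stand for stronger inhibition and higher numbers for weaker inhibition. Compound 1, `C=CCOc1ccc(F)cc1C(=O)c1cccnc1`, gives > 100000 nM in this assay, which is a limit of the measurement and not a number. Compound 2, `O=C(c1cccnc1)c1ccccc1O`, gives 33400 nM in this assay. On the numbers shown, compound 1 stands at the limit of > 100000 nM in this assay, at which 1 of the 2 values shown sits.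

Compound 3, `C=CCOc1ccc(Br)cc1C(=O)c1cccnc1`, has not yet been measured in this assay. It differs from compound 1 by bromo in place of fluoro on an aromatic carbon. For the measured compounds named here, no measured pair shows this exchange, so there is no measured step to lean on. Because compound 1 sits at the limit of > 100000 nM in this assay, at which 1 of the 2 values shown sits, the step of a number no higher from compound 1 to compound 3 (the limit leaves the size open) is expected to be none beyond the scatter. Compound 3 is therefore estimated at 100000 nM, with a range from 30000 nM to 300000 nM, and the result may again come back only as a limit.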

Compound 3, half-maximal inhibitory concentration: 59000 nM
Beside the measured number, compound 3's estimate is 1.7-fold (0.23 log units) above it, and the stated range covers the measured number.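

Bromo in place of fluoro on this aromatic carbon, para to the allyloxy group, gives an at least 1.6-fold lower number from compound 1 to compound 3 (0.22 log units; that floor lies within the scatter). Of the two compounds carrying the allyloxy group, only compound 3 returns a number in this assay, so this position now has one measured value, 59000 nM, though that value remains weak. The true size of the step stays unknown, since compound 1 holds only a limit of the assay and not a number: the limit of > 100000 nM in this assay, at which 1 of the 3 values shown sits.

The compounds shown leave open whether chloro, methoxy or an amine on the same aromatic carbon would move the number any further than bromo does. They also leave open whether bromo would have the same bearing with a longer chain or a carboxylic acid in place of the allyloxy group.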